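The source may hold more compounds than are shown below. What is called first, only, known or untested is meant among the compounds shown, and "the series" means these compounds.

Compound 1 `COc1nc(C)cc(SC)c1NC(=O)N(Cc1ccc(Oc2ccc(F)cc2)cc1)C1CCCCCC1`: < 0.032 mg/kg
Compound 2 `Cc1cc(Cl)c(NC(=O)N(Cc2ccc(Oc3ccc(F)cc3)cc2)C2CCCCCC2)c(Cl)n1`: > 0.1 mg/kg
Compound 3 `Cc1cc(S(C)(=O)=O)c(NC(=O)N(Cc2ccc(Oc3ccc(F)cc3)cc2)C2CCCCCC2)c(Cl)n1`: > 0.1 mg/kg

Each of these values is a limit and not a number. In a functional assay on the whole organism with Rattus norvegicus as the target (on this read-out higher numbers stand for an effect only at larger amounts of compound and lower numbers for an effect already at smaller amounts), compound 3 stands at the limit of > 0.1 mg/kg in this assay, at which 2 of the 3 values shown sit. Compound 4 `Cc1ccc(NC(=O)N(Cc2ccc(Oc3ccc(F)cc3)cc2)C2CCCCCC2)c(Cl)n1` has hydrogen in place of methylsulfonyl on an aromatic carbon, opposite the ring nitrogen (hydrogen in place of methylsulfonyl on an aromatic carbon).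

Going by the values given here, the one measured step at that place, a step that the two limits leave unreadable from compound 2 to compound 3, gives no size. The steps of an at least 3.1-fold higher number from compound 1 to compound 2 (0.49 log units; beyond the scatter) and an at least 3.1-fold higher number from compound 1 to compound 3 (0.49 log units; beyond the scatter) lie beyond the scatter, but each exchanges the whole group on the amide-type nitrogen. Given an at least 3.1-fold higher number from compound 1 to compound 3 (0.49 log units; beyond the scatter), compound 4 is expected to stay closer to compound 3 than to compound 1, with no clear step beyond the scatter. The estimated step is a step that the limit leaves unreadable from compound 3 to compound 4. For compound 4 the expected value is 0.2 mg/kg, with an estimated range from 0.05 mg/kg to 1 mg/kg.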

Compound 4, dose for half-maximal effect: > 0.1 mg/kg
Compound 4 gave a limit, no number; the forecaster's own chance of this, stated with the estimate: 70%; the middle value does not contradict the limit.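

With hydrogen opposite the ring nitrogen, compound 4 still gives only a limit in this assay, as do the chloro compound 2 and the methylsulfonyl compound 3, so the steps among these three cannot be read. Hydrogen at this place also stays apart from the core of compound 1, with an at least 3.1-fold higher number from compound 1 to compound 4 (0.49 log units; beyond the scatter), though that step exchanges the whole group on the amide-type nitrogen. Compound 4 joins the shared limit: the limit of > 0.1 mg/kg in this assay, at which 3 of the 4 values shown sit.

As far as these compounds go, the true values of compound 2, compound 3 and compound 4 remain open. So does whether an amine on this aromatic carbon would give a readable value.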